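This account rests on a few compounds, and the source may have more. Where it says the series, first, only, none or still open, it means among the compounds named here.

Measured so far in an ADME assay on a cell-free system (plasma, Mus musculus) for protein binding, using ultracentrifugation; on this read-out higher numbers stand for a larger free fraction and lower numbers for a smaller free fraction:
- compound 1 `CCNC(=O)Nc1nc2cc(-c3cnc(C(C)(C)O)nc3)cc(-c3cc(CN4CC(C)(O)C4)ccn3)c2s1`: 0.223
- compound 2 `CCNC(=O)Nc1nc2cc(-c3cnc(C(C)(C)O)nc3)cc(-c3cc(CN4CC(OC)C4)ccn3)c2s1`: 0.11
- compound 3 `CCNC(=O)Nc1nc2cc(-c3cnc(C(C)(C)O)nc3)cc(-c3cc(CN4CC[C@@H](O)C4)ccn3)c2s1`: 0.194

Compound 2 holds the lowest of the three numbers. Its gap to compound 3 lies within the scatter, so no order between these two can be read; its gap to compound 1 lies beyond it, seen as a 2.0-fold lower number from compound 1 to compound 2 (0.31 log units; beyond the scatter).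

Compound 4 `CCNC(=O)Nc1nc2cc(-c3cnc(C(C)(C)O)nc3)cc(-c3cc(CN4CC(O)C4)ccn3)c2s1` differs from compound 2 by hydrogen in place of methyl on an oxygen on a saturated carbon.

The bearing steps are those that exchange the methoxy-bearing azetidine for a hydroxy-bearing ring: a 1.8-fold higher number from compound 2 to compound 3 (0.25 log units; within the scatter), and, read the other way, a 2.0-fold lower number from compound 1 to compound 2 (0.31 log units; beyond the scatter). Both hydroxy-bearing rings give higher numbers than compound 2, one beyond and one within the scatter. Compound 4 carries a hydroxy group too, but neither the methyl of compound 1 nor the larger ring of compound 3, so a moderate rise toward their values is expected rather than a step past them: the expected step is a 1.7-fold higher number from compound 2 to compound 4 (0.24 log units; within the scatter).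

For compound 4 in this assay the estimate is 0.19, with a range from 0.11 to 0.32.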

Compound 4, unbound fraction: 0.22
Estimate against measurement, compound 4: 1.2-fold (0.06 log units) below; low and high end bracket the measured number.
By their numbers in this assay, from the lowest: compounds 2, 3, 4 and 1 (each within the scatter of the next, the first and the last beyond it).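

In this assay, hydrogen in place of methyl on the oxygen gives a step that stays inside the scatter (a 2.0-fold higher number from compound 2 to compound 4 (0.30 log units; within the scatter)), so methoxy to hydroxy on this azetidine does not separate on its own, even though compound 1 does stand apart from compound 2. The methyl on the saturated ring carbon (a 1.0-fold lower number from compound 1 to compound 4 (0.01 log units; within the scatter)) and the change of ring from 3-hydroxypyrrolidin-1-yl to 3-hydroxyazetidin-1-yl (a 1.1-fold higher number from compound 3 to compound 4 (0.05 log units; within the scatter)) leave no readable difference, so compound 1, compound 3 and compound 4 cannot be ordered. No measured evidence bears on this result.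

Open, from the compounds shown here alone, is how a 3-aminoazetidin-1-yl or 3-carboxyazetidin-1-yl group would read in this place. Also open, going by these compounds, is whether a longer chain on the oxygen, such as ethoxy, would give a step beyond the scatter.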